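Removing the Terminal Carbamoyl Group from Compound 3

The compounds below may be only part of what the source reports. "The series", "measured", "known", "first", "only" and "open" are said of these compounds alone.

Compound 1 `CC[C@H](C)[C@H](NC(=O)[C@@H]1CCC(=O)N1)C(=O)N1CCC[C@H]1C(N)=O`: 10%
Compound 2 `CCCCCCCCCCNC(=O)[C@H]1CCCN1C(=O)[C@@H](CC(C)C)NC(=O)[C@H]1CCC(=O)N1`: 10%
Compound 3 `CC(C)C[C@@H](NC(=O)[C@H]1CCC(=O)N1)C(=O)N1CCC[C@@H]1C(=O)NCCN(C)C`: 10%

In a functional assay on the whole organism for inhibition, with Rattus norvegicus as the target, at a dose of 80 mg/kg by the intravenous route (a lower number here means less inhibition, a higher number more inhibition at the dose given (going by the name of the read-out)), compound 1 gives 10%. In this assay compound 2 gives 10%, and compound 3 gives 10%. Among the compounds with values here, compound 3 therefore sits level with both of the other measured compounds; the one step that can be traced, no change at the digits printed from compound 2 to compound 3 (within the scatter), replaced dimethylamino with octyl on a saturated chain carbon, two bonds along the chain from an amide-type nitrogen, and left the read-out where it was.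

Compound 4 `CC(C)C[C@@H](NC(=O)[C@H]1CCC(=O)N1)C(=O)N1CCCC1` differs from compound 3 as follows: hydrogen in place of (2-(dimethylamino)ethyl)carbamoyl on a saturated ring carbon. Within the data shown here, the only measured step that bears on this change is the one from compound 2 to compound 3, which also reworked the group hanging from that saturated ring carbon and showed no movement. On that basis the step of no change at the digits printed from compound 3 to compound 4 (within the scatter) is expected to stay within the scatter. Compound 4 is thus estimated to give 10% in this assay, with a likely range from 0% to 25%.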

Compound 4, a percentage reported as inhibition, in the whole organism at one dose (the size of the read-out at that dose, not a potency): 20%
The estimate for compound 4 lay 10 percentage points below the measured number, within the range that was stated.
By their numbers in this assay, from the lowest: compounds 1, 2, 3 and 4 (each within the scatter of the next).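

Within the data shown here, the step from the (2-(dimethylamino)ethyl)carbamoyl group to hydrogen on the saturated ring carbon gives, in this assay, a number 10 percentage points higher from compound 3 to compound 4 (within the scatter) and extends what the earlier compounds showed. The earlier step only reworked the group carried at this carbon, whereas this one removes that group entirely. For this pair, therefore, the read-out in the whole animal stays within the scatter with no large group at this place. Nothing at hand offers an explanation for this result.

As far as these compounds go, whether a carboxylic acid or a hydroxymethyl group at this saturated ring carbon would move the read-out beyond the scatter remains open. So does whether removing the carbamoyl group from compound 1 would give the same outcome on that core.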